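The source may hold more compounds than are shown below. What is called first, only, known or untested is meant among the compounds shown, and "the series" means these compounds.

Measured compounds in an ADME assay on the whole organism with Oryza sativa as the target, tested at 0.1 uM; a higher number here means a weaker effect of the compound at the concentration tested, a lower number a stronger effect:

Compound 1: `CCCc1ccc(NC(=O)N[C@H](C)c2ccccc2)cc1`, 33%
Compound 2: `CCCc1ccc(NC(=O)N[C@@H](C)c2ccccc2)cc1`, 97%

Within the data shown here, compound 2 stands highest of the two numbers measured so far in this assay; its only neighbour is compound 1, and the single measured step between them is a number 64 percentage points higher from compound 1 to compound 2 (beyond the scatter). That step is tied to the fact that compounds 1 and 2 differ only in the configuration as drawn, so it concerns the configuration at the saturated chain carbon and nothing else about the molecule.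

Compound 3 `CCCCc1ccc(NC(=O)N[C@@H](C)c2ccccc2)cc1` keeps the configuration of compound 2 and differs from it by methyl in place of hydrogen on a saturated chain carbon, three bonds along the chain from an aromatic carbon. Among the measured compounds shown here, no measured step touches a change of this kind: the one step in hand compares two drawings of the same atoms and bonds, and the propyl chain is untouched in both. There is therefore no measured basis for expecting the lengthening of the chain to move the number beyond the scatter in either direction in this assay.

Compound 3 is estimated at 92%, with a range from 65% to 100%. The step this estimate implies is a number 5 percentage points lower from compound 2 to compound 3 (within the scatter), which is expected to lie within the scatter.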

Compound 3, a percentage reported as activity, at one concentration (the size of the read-out at that concentration, not a potency): 98%
Beside the measured number, compound 3's estimate is 6 percentage points below it, and the stated range covers the measured number.
By their numbers in this assay, from the lowest: compound 1; then compounds 2 and 3 (each within the scatter of the next).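

In this assay, methyl in place of hydrogen on a saturated chain carbon, three bonds along the chain from an aromatic carbon, turns propyl into butyl and gives a number 1 percentage points higher from compound 2 to compound 3 (within the scatter). In the configuration drawn in compound 2, then, the read-out does not distinguish these two chain lengths, whereas the earlier pair showed only the effect of configuration, with a number 64 percentage points higher from compound 1 to compound 2 (beyond the scatter). What is known about these compounds concerns configuration alone and says nothing about this chain.

The compounds shown leave open whether butyl would also leave the number unmoved in the configuration of compound 1, which gives 33% and so shows a stronger effect at the concentration tested. They also leave open how a longer chain such as pentyl, or an amine or carboxylic acid at the chain end, would read in this assay.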